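A few compounds are considered here, and "the series" means these few. Any claim that something is new, unique, unknown or untested is made for them only; others in the source may bear on it.

Measured compounds:
- compound 1, `COc1ccc(CN2C(=O)C(=O)c3cc(/C=C/C(=O)OCCO)ccc32)cc1`, a functional assay on K562 cells (Homo sapiens) for cytotoxicity, read by MTT assay, with a stated time of 48 h; on this read-out higher numbers stand for weaker inhibition and lower numbers for stronger inhibition: 40 nM
- compound 2, `COC(=O)/C=C/c1ccc2c(c1)/C(=N/O)C(=O)N2Cc1ccc(OC)cc1`, in this assay: 2110 nM

Of the two numbers, compound 1 holds the lower one, and the gap to compound 2 lies beyond the scatter of this kind of measurement. Compound 2 differs from compound 1 in more than one place, so its value says nothing by itself about any single change. The unmeasured compound 3, `CCOC(=O)/C=C/c1ccc2c(c1)C(=O)C(=O)N2Cc1ccc(OC)cc1`, is reached from compound 1 by one change only: hydrogen in place of hydroxy on a saturated chain carbon, two bonds along the chain from an oxygen next to a carbonyl group. The hydroxy sits at the far end of the ester chain, away from the shared core, and the rest of compound 1 is kept. Among the compounds with values here, no measured pair isolates this change, so the direction cannot be read from the data; a step within the scatter, or a little beyond it, is expected in this assay. The number for compound 3 is estimated at 60 nM, within 20 nM to 200 nM, which means an expected step of a 1.5-fold higher number from compound 1 to compound 3 (0.18 log units; within the scatter).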

Compound 3, half-maximal inhibitory concentration: 10 nM
Beside the measured number, compound 3's estimate is 6.0-fold (0.78 log units) above it, outside the stated range (below it).
By their numbers in this assay, from the lowest: compound 3; then compound 1; then compound 2.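

In this assay, within the data shown here, hydrogen in place of hydroxy on a saturated chain carbon, two bonds along the chain from an oxygen next to a carbonyl group, gives a 4.0-fold lower number from compound 1 to compound 3 (0.60 log units; beyond the scatter), the first single change that can be read. It shows that this position responds to a small edit, and that the free hydroxy of the 2-hydroxyethyl group is not required for a low number, since compound 3, with the plain ethyl group, gives 10 nM in this assay. Nothing at hand explains why the step runs in this direction.

With a single step at this position, the compounds shown leave open whether the trend continues beyond the change from 2-hydroxyethoxy to ethoxy, for instance with an amine or a carboxylic acid at the end of the chain, or with a longer chain such as propyl or butyl. They also leave open whether the same change would give a step of similar size with the rest of the molecule altered, since it is seen here on the core of compound 1 alone.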